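The compounds below may be only part of what the source reports. "The series", "measured", "known", "first", "only" and "open" are said of these compounds alone.

Compound 1, `COc1ccc(/C=C/C(=O)O)c(OC(=O)c2nc(C)c(C)nc2C)c1`: 134000 nM in a functional assay on a cell-free system (Platelet, plasma, Oryctolagus cuniculus) for inhibition, with a stated time of 5 min, at 37 degrees C; on this read-out lower numbers stand for stronger inhibition and higher numbers for weaker inhibition
Compound 2, `CCOC(=O)/C=C/c1ccc(OC)cc1OC(=O)c1nc(C)c(C)nc1C`: 28200 nM
Compound 3, `COc1cc(/C=C/C(=O)O)cc(OC)c1OC(=O)c1nc(C)c(C)nc1C`: 82300 nM

Of the compounds shown here, three have been measured in this assay, and a fourth, compound 4 with the structure `CCOC(=O)/C=C/c1cc(OC)c(OC(=O)c2nc(C)c(C)nc2C)c(OC)c1`, awaits its measurement. Compound 2 is obtained from compound 1 by a single change, (ethyl in place of hydrogen on an oxygen next to a carbonyl group), and that change produced a 4.8-fold lower number from compound 1 to compound 2 (0.68 log units; beyond the scatter). Compound 4 is obtained from compound 3 by the same change, (ethyl in place of hydrogen on an oxygen next to a carbonyl group), at the same place. The difference between the core of compound 1 and the core of compound 3 is not broken down here; the two differ in more than one place. In this assay compound 1 gives 134000 nM and compound 3 gives 82300 nM; the two values lie within the usual scatter of each other, so nothing is made of their order.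

Since the change from compound 3 to compound 4 repeats what was done from compound 1 to compound 2, the step is expected to be of a similar size, and the estimate for compound 4 is a 4.3-fold lower number from compound 3 to compound 4 (0.64 log units; beyond the scatter), resting on the measured step of a 4.8-fold lower number from compound 1 to compound 2 (0.68 log units; beyond the scatter). The number expected for compound 4 is therefore 19000 nM, with a likely range from 7000 nM to 50000 nM; this single precedent is the only support, so the range is kept wide.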

Compound 4, half-maximal inhibitory concentration: 37500 nM
For compound 4 the middle estimate is 2.0-fold (0.30 log units) below the measured one; the measured number falls inside the stated range.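

In this assay, the change from carboxy to ethoxycarbonyl on the second core gave a 2.2-fold lower number from compound 3 to compound 4 (0.34 log units; beyond the scatter), a step beyond the scatter and in the same direction as the one seen on the first core. Set side by side, the two steps share a direction and cannot be told apart in size: the same change on two cores in this assay, a 4.8-fold lower number (0.68 log units; beyond the scatter) from compound 1 to compound 2 and a 2.2-fold lower number (0.34 log units; beyond the scatter) from compound 3 to compound 4, 2.2-fold (0.34 log units) apart, within the scatter of two such steps. This shows that the change carried over from the core of compound 1 to the core of compound 3, but with one pair on each core it does not show that the change would carry to any other core in the series, and it says nothing about what lies behind the step.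

The compounds shown leave open how a methyl ester, a longer alkyl chain or an amide would compare with the ethyl ester on either core. They also leave open what each separate difference between the two cores does on its own, since those cores differ in more than one place and that difference is not broken down here.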